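A few compounds are considered here, and "the series" means these few. Any claim that something is new, unique, unknown or untested is made for them only; others in the source may bear on it.

Measured compounds in this series:
- compound 1, `C#CCN(c1nc(-c2cccc(Br)c2)no1)C1CCCCC1`, 31.8 ug/mL in an ADME assay on RAW264.7 cells (Mus musculus) for cytotoxicity, read by MTT assay, with a stated time of 48 h; on this read-out higher numbers stand for lower toxicity in this test and lower numbers for higher toxicity in this test
- compound 2, `CC(=O)OC[C@H]1O[C@H](OC[C@@H](Cn2cc(CN(c3nc(-c4cccc([N+](=O)[O-])c4)no3)C3CCCCC3)nn2)OC(C)=O)C=C[C@@H]1OC(C)=O`, 100 ug/mL in this assay
- compound 3, `C#Cc1ccc(-c2noc(NC3CCCCC3)n2)cc1`, 19.8 ug/mL in this assay

Compound 2 gives the highest of the three numbers in this assay, that is the lowest toxicity among them. Its nearest neighbour on the scale is compound 1, whose number is lower by an amount beyond the usual scatter; compound 3 lies further away, also beyond the scatter. Going by the values given here, no pair of these three compounds differs in a single place, so no single step can be read from the measured set; the gap between compound 2 and compound 1, or between compound 2 and compound 3, involves several changes at once and is recorded here only as what the two numbers show.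

Compound 4, `CC(=O)OC[C@H]1O[C@H](OC[C@@H](Cn2cc(CN(c3nc(-c4ccc([N+](=O)[O-])cc4)no3)C3CCCCC3)nn2)OC(C)=O)C=C[C@@H]1OC(C)=O`, is not yet measured. It differs from compound 2 by 4-nitrophenyl in place of 3-nitrophenyl on an aromatic carbon. Among the compounds with values here, the change keeps the same atoms and only moves the nitro group around the ring; no pair of measured compounds shows what such a move does here. The expectation is a step from compound 2 to compound 4 of a 1.2-fold lower number from compound 2 to compound 4 (0.07 log units; within the scatter), that is none beyond the scatter. Compound 4 is therefore estimated at 85 ug/mL in this assay, with a range from 45 ug/mL to 100 ug/mL.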

Compound 4, half-maximal cytotoxic concentration: 64.1 ug/mL
Compound 4: middle estimate off by 1.3-fold (0.12 log units), on the high side, and the stated range covers the measured number.
By their numbers in this assay, from the lowest: compounds 3, 1, 4 and 2 (each within the scatter of the next, the first and the last beyond it).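

In this assay, going by these compounds alone, the pair of compound 2 and compound 4 gives the only single-place comparison so far: 4-nitrophenyl in place of 3-nitrophenyl, on the aromatic carbon between two ring nitrogen atoms, amounts to a 1.6-fold lower number from compound 2 to compound 4 (0.19 log units; within the scatter) and stays within the usual scatter. With the rest of the molecule held fixed, the two nitrophenyl isomers therefore cannot be told apart on this read-out, and moving the nitro group around the ring does not reproduce the larger gaps seen between compound 2 and compounds 1 and 3. Nothing measured on these compounds bears on this result.

Open, from the compounds shown here alone, is whether a different group on the phenyl ring at this place, such as an amine or a carboxylic acid, would give a step beyond the scatter. Also open is which of the several differences separating compound 2 and compound 4 from compounds 1 and 3 accounts for those gaps, since neither compound 1 nor compound 3 differs from either of them in one place.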